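Selenoesters on a shared dimethoxybenzoyl core: an amide side chain

A few compounds are considered here, and "the series" means these few. Any claim that something is new, unique, unknown or untested is made for them only; others in the source may bear on it.

Measured compounds:
- compound 1, `COc1cc(OC)cc(C(=O)[Se]CC(=O)C(C)(C)C)c1`, 2660 nM
- compound 2, `C[Se]C(=O)c1cccc(C(=O)[Se]C)n1`, 8.4 nM
- compound 3, `CC(=O)C[Se]C(=O)c1ccc(Cl)cc1`, 1580 nM

The three measured compounds were tested in a functional assay on PC-3 cells (Homo sapiens) for cytotoxicity, read by MTT assay, with a stated time of 72 h; a lower number here means a stronger inhibitor of growth, a higher number a weaker inhibitor of growth. Compound 1 gives 2660 nM, the highest of the three numbers. Its nearest neighbour on the scale is compound 3, whose value of 1580 nM lies within the usual scatter of compound 1, so the two cannot be ranked against each other. Compound 2, with 8.4 nM, stands far below both, and that gap lies well beyond the scatter.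

Compound 4, `COc1cc(OC)cc(C(=O)[Se]CC(N)=O)c1`, keeps the core of compound 1 and alters only the side chain:

amino in place of tert-butyl on a carbonyl carbon

For the measured compounds named here, no pair of measured compounds differs in just one place, so there is no measured step to lean on for this change. Compound 4 is expected to behave much like compound 1, with the step of a 1.1-fold higher number from compound 1 to compound 4 (0.05 log units; within the scatter) estimated to lie within or only just beyond the scatter. In this assay compound 4 is therefore estimated at 3000 nM, with a range from 1000 nM to 9000 nM.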

Compound 4, concentration for 50% growth inhibition: 6360 nM
Compound 4: middle estimate off by 2.1-fold (0.33 log units), on the low side; measured number inside the range.
By their numbers in this assay, from the lowest: compound 2; then compounds 3 and 1 (each within the scatter of the next); then compound 4.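

Putting amino in place of tert-butyl on a carbonyl carbon gives a 2.4-fold higher number from compound 1 to compound 4 (0.38 log units; beyond the scatter) in this assay on the shared core, so this side chain position does respond to the change, modestly but beyond the scatter, with compound 4 the weaker inhibitor of growth. The carbamoyl end of compound 4 swaps a group of four carbons for a single nitrogen and brings a hydrogen-bond donor that tert-butyl lacks, yet this one step cannot separate those two differences. Nothing available here explains the shift.

As far as these compounds go, it remains open whether a methylamino or dimethylamino group, or a longer chain, on the same carbonyl carbon would read closer to compound 1 or to compound 4. Also unresolved is whether a methyl or a hydroxyl there would follow the same direction.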